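Hydrazone series: predicting the methoxy analogue of compound 3

The source may hold more compounds than are shown below. What is called first, only, known or untested is meant among the compounds shown, and "the series" means these compounds.

Measured so far:
compound 1 `O=C(N/N=C/c1ccc(F)cc1)c1cccnc1Nc1cccc(C(F)(F)F)c1`: 41.2%
compound 2 `O=C(N/N=C/c1cccc(Cl)c1)c1cccnc1Nc1cccc(C(F)(F)F)c1`: 63.5%
compound 3 `O=C(N/N=C/c1cccc(O)c1)c1cccnc1Nc1cccc(C(F)(F)F)c1`: 65.4%

Compound 3 holds the highest number of the three in a functional assay on the whole organism (strain Wistar) for inhibition, with Rattus norvegicus as the target, read by paw edema, with a stated time of 2 h, at a dose of 10 mg/kg by the intraperitoneal route (a lower number here means less inhibition, a higher number more inhibition at the dose given (going by the name of the read-out)), though against compound 2 the gap is a number 1.9 percentage points higher from compound 2 to compound 3 (within the scatter), so the two are not separable. Compound 1 sits well apart from both: a number 24.2 percentage points higher from compound 1 to compound 3 (beyond the scatter) and a number 22.3 percentage points higher from compound 1 to compound 2 (beyond the scatter).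

Compound 4 `COc1cccc(/C=N/NC(=O)c2cccnc2Nc2cccc(C(F)(F)F)c2)c1` is not yet measured. Relative to compound 3 it carries methyl in place of hydrogen on an oxygen on an aromatic ring. Within the data shown here, no measured step covers a methyl in place of hydrogen on an oxygen. The nearest information is the exchange of chloro for hydroxy on the same aromatic carbon, which gave a number 1.9 percentage points higher from compound 2 to compound 3 (within the scatter); a heavier group at that position thus left the number unchanged within the scatter, while the larger shifts came only from moving a substituent around the ring. On that basis the step is expected to stay small, a number 5.4 percentage points lower from compound 3 to compound 4 (within the scatter). Compound 4 is therefore estimated at 60%, with a range of 45% to 75%.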

Compound 4, a percentage reported as inhibition, in the whole organism at one dose (the size of the read-out at that dose, not a potency): 49.7%
Compound 4: middle estimate off by 10.3 percentage points, on the high side, within the range that was stated.
By their numbers in this assay, from the lowest: compounds 1 and 4 (each within the scatter of the next); then compounds 2 and 3 (each within the scatter of the next).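

Capping the hydroxy is the first change on this aromatic carbon to shift the number in this assay beyond the scatter, with a number 15.7 percentage points lower from compound 3 to compound 4 (beyond the scatter) as the step, so methyl in place of hydrogen on this oxygen is not a neutral change. The chloro and hydroxy groups could be exchanged within the scatter, but methoxy is not a third equivalent, as a number 13.8 percentage points lower from compound 2 to compound 4 (beyond the scatter) shows. The 3-methoxyphenyl and 4-fluorophenyl compounds are not separated, with a number 8.5 percentage points higher from compound 1 to compound 4 (within the scatter) as the step, so a substituent at the 3-position of the phenyl does not by itself give the higher numbers of compound 2 and compound 3.

As far as these compounds go, whether an amine or an ethoxy group on the same carbon would group with compound 3 or with compound 4 remains open. Nothing available accounts for the effect of the methyl on this oxygen.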